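From fluoro to hydrogen at the top of the range

This account rests on a few compounds, and the source may have more. Where it says the series, first, only, none or still open, it means among the compounds named here.

Results in a functional assay on Vero cells (Chlorocebus sabaeus) for cytotoxicity; on this read-out lower numbers stand for stronger inhibition and higher numbers for weaker inhibition:
- compound 1 `Nc1nc(=O)n([C@H]2C=C[C@@H](CO)O2)cc1Br` gives > 100000 nM (a limit)
- compound 2 `CC(=O)Nc1nc(=O)n([C@H]2C=C[C@@H](CO)O2)cc1F` gives 103000 nM
- compound 3 `Nc1nc(=O)n(C2C=CC(CO)C2)cc1F` gives > 100000 nM (a limit)

Compound 3 stands at > 100000 nM in this assay, which is a limit and not a number. It is not alone there, as the set shows (the limit of > 100000 nM in this assay, at which 2 of the 3 values shown sit). Compound 2 is the only one of the three with a number, 103000 nM.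

Compound 4 `Nc1ccn(C2C=CC(CO)C2)c(=O)n1` differs from compound 3 by hydrogen in place of fluoro on an aromatic carbon, ortho to an amino group: hydrogen in place of fluoro on an aromatic carbon. For the measured compounds named here, no measured pair shows this change on its own. In this assay no step beyond the scatter is expected, and neither direction is favoured. That expectation rests on compound 3, with its limit of > 100000 nM. The estimated step is a number no higher from compound 3 to compound 4 (the limit leaves the size open). For compound 4 the estimated value is 100000 nM, with an expected range from 40000 nM to 250000 nM.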

Compound 4, half-maximal inhibitory concentration: > 100000 nM
Compound 4: no number, only a limit (the forecaster's own chance of this, stated with the estimate: 70%); the middle value sits exactly at the limit.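

In this assay, for the compounds shown here, compound 3 and compound 4 both give a limit and not a number, so no step between them can be read: the limit of > 100000 nM in this assay, at which 3 of the 4 values shown sit. The compounds shown leave open whether hydrogen in place of fluoro on an aromatic carbon changes this read-out at all.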